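Adding a Trimethoxyphenyl Ring to a Chalcone Series

The source may hold more compounds than are shown below. What is called first, only, known or untested is meant among the compounds shown, and "the series" means these compounds.

Measured so far:
compound 1 `O=C(/C=C/c1cccc(O)c1)c1cccc(-n2cc(-c3ccc(Cl)cc3)[nH]c2=O)c1`, 1780 nM
compound 2 `COc1cc(/C=C/C(=O)c2cccc(-n3cc(-c4ccccc4)[nH]c3=O)c2)cc(OC)c1OC`, 1920 nM

Both compounds were tested in a functional assay on SF-268 cells (Homo sapiens) for inhibition; a lower number here means a stronger inhibitor of growth, a higher number a weaker inhibitor of growth. Compound 2 has the higher of the two numbers, and the nearest compound is compound 1, yet the gap between them lies within the scatter, so the two cannot be told apart on these numbers alone.

Compound 3 `COc1cc(/C=C/C(=O)c2cccc(-n3cc(-c4cc(OC)c(OC)c(OC)c4)[nH]c3=O)c2)cc(OC)c1OC` has not yet been measured. It differs from compound 2 in one place: 3,4,5-trimethoxyphenyl in place of phenyl on an aromatic carbon. Within the data shown here, nothing measured shows what this change does, since no two measured compounds differ by it.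

Among the measured compounds shown here, with no measured step to lean on, the expectation for compound 3 is a number close to that of compound 2, with any shift being small and possibly not beyond the scatter; the expected step is a 1.3-fold lower number from compound 2 to compound 3 (0.11 log units; within the scatter). Compound 3 is therefore estimated at 1500 nM, within a range from 500 nM to 4500 nM.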

Compound 3, concentration for 50% growth inhibition: 2200 nM
Compound 3: middle estimate off by 1.5-fold (0.17 log units), on the low side, within the range that was stated.
By their numbers in this assay, from the lowest: compounds 1, 2 and 3 (each within the scatter of the next).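

Among these compounds, replacing phenyl with 3,4,5-trimethoxyphenyl gives the first step that can be read at this position, on an aromatic carbon of the five-membered ring, and in this assay it amounts to a 1.1-fold higher number from compound 2 to compound 3 (0.06 log units; within the scatter). The incoming group carries more heavy atoms than phenyl, including oxygen, yet compound 2 and compound 3 cannot be told apart on this read-out, so this position accepts the larger group with no visible gain or loss. No accompanying measurement offers an explanation for this result.

As far as these compounds go, it remains open whether any group at this position can move the number beyond the scatter, for instance an amine or a carboxylic acid in place of the ring. From the compounds shown here alone, it is also open whether this swap would give a similar step if the other trimethoxyphenyl ring of compound 2 were replaced.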